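The source may hold more compounds than are shown below. What is called first, only, known or untested is meant among the compounds shown, and "the series" means these compounds.

Going by the values given here, in a functional assay (Homo sapiens) (on this read-out lower numbers stand for stronger inhibition and higher numbers for weaker inhibition), compound 1 (`Nc1nc2ccnc(-c3cccc(OC(F)F)c3)n2n1`) gives 3400 nM; 3400 nM (2 entries), while compound 2 (`Nc1nc2ccnc(-c3cccc(C(Cl)Cl)c3)n2n1`) gives 1000 nM, the lower of the two numbers so far. Compound 3 (`Nc1nc2ccnc(-c3cccc([N+](=O)[O-])c3)n2n1`) carries nitro in place of dichloromethyl on an aromatic carbon of the six-membered ring of carbon only (nitro in place of dichloromethyl on an aromatic carbon). Among the compounds with values here, no measured pair shows this kind of change, and any forecast stays loose. A modest move toward weaker inhibition in this assay is expected, and the estimated size is a 1.8-fold higher number from compound 2 to compound 3 (0.26 log units; within the scatter). For compound 3 the estimate is 1800 nM, with an expected range of 500 nM to 6500 nM.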

Compound 3, half-maximal inhibitory concentration: 3800 nM
The estimate for compound 3 lay 2.1-fold (0.32 log units) below the measured number; low and high end bracket the measured number.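

In this assay, this position proves sensitive to the group it carries, with a 3.8-fold higher number from compound 2 to compound 3 (0.58 log units; beyond the scatter) when nitro replaces dichloromethyl on the aromatic carbon. Both groups have the same count of heavy atoms, so that count alone does not set the number here. Nothing measured bears on why the number moves. On these data alone, whether an amine, a carboxylic acid or a nitrile on this carbon would give a lower number than compound 2 remains open. So does whether a simple chlorine atom there would keep the number of compound 2.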